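From 4-fluorobenzyl to 2-chlorobenzyl on the shared core

The source may hold more compounds than are shown below. What is called first, only, known or untested is meant among the compounds shown, and "the series" means these compounds.

Compound 1 (`COc1ccc(/C=C2\CN(C(=S)SCc3cn(Cc4ccccc4F)nn3)C/C(=C\c3ccc(OC)cc3)C2=O)cc1`) with (54500 nM)
Compound 2 (`Cc1ccc(/C=C2\CN(C(=S)SCc3cn(Cc4ccc(F)cc4)nn3)C/C(=C\c3ccc(C)cc3)C2=O)cc1`) with (38800 nM)

In a functional assay on DU-145 cells (Homo sapiens) for cytotoxicity, read by MTT assay, with a stated time of 24 h (on this read-out higher numbers stand for weaker inhibition and lower numbers for stronger inhibition), compound 2 gives 38800 nM and compound 1 gives 54500 nM within the usual scatter of each other, so neither can be ranked ahead. Compound 3 (`Cc1ccc(/C=C2\CN(C(=S)SCc3cn(Cc4ccccc4Cl)nn3)C/C(=C\c3ccc(C)cc3)C2=O)cc1`) keeps the core of compound 2 and carries 2-chlorophenyl in place of 4-fluorophenyl on a saturated chain carbon bound to an aromatic nitrogen. Within the data shown here, no measured pair isolates this change, so the data give no direct guide to its size or direction. Among the measured compounds shown here, the two values so far lie close together, and no step beyond the scatter is expected in this assay from this exchange. The estimated step runs a 1.0-fold higher number from compound 2 to compound 3 (0.01 log units; within the scatter) and has no favoured direction. The estimated value for compound 3 is 40000 nM (expected range 20000 nM to 75000 nM).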

Compound 3, half-maximal inhibitory concentration: > 80000 nM
Compound 3 gave a limit, no number; the forecaster's own chance of this, stated with the estimate: 5%; middle value at least 2.0-fold (0.30 log units) from the limit.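

In this assay compound 3 gives > 80000 nM, which is a limit of the assay and not a number. Among these compounds, the exchange of 4-fluorobenzyl for 2-chlorobenzyl yields the first readable step at this place, on a saturated chain carbon bound to an aromatic nitrogen: an at least 2.0-fold higher number from compound 2 to compound 3 (0.31 log units; beyond the scatter). This shows that the position is not indifferent to this exchange, which compound 1 and compound 2 could not show, but the full size of the step stays unknown because only its minimum can be read: the limit of > 80000 nM in this assay, at which 1 of the 3 values shown sits.

From the compounds shown here alone, whether the loss follows the chlorine or its place on the ring stays open, and a 4-chlorobenzyl group on the core of compound 2 would separate the two. Also open, going by these compounds, is how an unsubstituted benzyl group or a longer chain such as phenethyl would read at this place.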